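The source may hold more compounds than are shown below. What is called first, only, known or untested is meant among the compounds shown, and "the series" means these compounds.

Measured compounds:
Compound 1 `CCN(Cc1ccccc1)C(=O)C1CCN(S(=O)(=O)c2ccccc2)CC1` — 69%
Compound 2 `CCN(Cc1ccccc1)C(=O)C1CCN(S(=O)(=O)c2cccc(OC)c2)CC1` — 77%
Compound 3 `CCN(Cc1ccccc1)C(=O)C1CCN(S(=O)(=O)c2ccccc2OC)CC1` — "not determined" (no result reported)

In a functional assay on CHO cells for positive allosteric modulation of muscarinic acetylcholine receptor M5 (Homo sapiens), read by calcium flux (a higher number here means a larger maximal response, a lower number a smaller maximal response), compound 1 gives 69% and compound 2 gives 77%; the step of a number 8 percentage points higher from compound 1 to compound 2 (within the scatter) stays within the scatter. For compound 3 this assay gives "not determined" (no result reported), so compound 3 stands without a single number, and its position can only be read from compounds 1 and 2, which sit close together.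

Compound 4 `CCN(Cc1ccccc1)C(=O)C1CCN(S(=O)(=O)c2cccc3c2OCCO3)CC1` differs from compound 3 in one place: 2,3-dihydro-1,4-benzodioxin-5-yl in place of 2-methoxyphenyl on a sulfonyl sulfur. Within the data shown here, the only measured step, from compound 1 to compound 2, adds an oxygen-bearing group on the aromatic ring and stays within the scatter, so no step beyond the scatter is expected here either. Compound 4 is therefore estimated to reach 73% in this assay, with a range from 52% to 94%.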

Compound 4, largest response reached (reported as percent of maximum), in percent of the reference or control that the assay uses: 53%
Estimate against measurement, compound 4: 20 percentage points above, and the stated range covers the measured number.
By their numbers in this assay, from the lowest: compound 4; then compounds 1 and 2 (each within the scatter of the next).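

The aryl group on the sulfonyl sulfur can change the maximal response in this assay: the 2,3-dihydro-1,4-benzodioxin-5-yl group gives a number 24 percentage points lower from compound 2 to compound 4 (beyond the scatter) and a number 16 percentage points lower from compound 1 to compound 4 (beyond the scatter). Oxygen on the aromatic ring does not always lower the response, and compound 2, with its 3-methoxyphenyl group, goes against that reading. Nothing available explains the drop.

Compound 3 has no number, so the step from its 2-methoxyphenyl group to the group of compound 4 cannot be read. From the compounds shown here alone, how an amine or a carboxylic acid on this aromatic ring would fare also remains open.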